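The source may hold more compounds than are shown below. What is called first, only, known or untested is meant among the compounds shown, and "the series" means these compounds.

Measured compounds in a functional assay on SK-MEL-2 cells (Homo sapiens) for cytotoxicity; on this read-out lower numbers stand for stronger inhibition and higher numbers for weaker inhibition:
- compound 1, `Cc1nn(C)c(-n2cccc2)c1/C=N/OCc1ccc(C(=O)OC(C)(C)C)cc1`: 24.9 ug/mL
- compound 2, `Cc1nn(C)c(Oc2ccc(Cl)cc2)c1/C=N/OCc1ccc(C(=O)OC(C)(C)C)cc1`: 18.8 ug/mL

For the measured compounds named here, compound 2 carries the second of the two numbers in this assay; the only measured step, a 1.3-fold lower number from compound 1 to compound 2 (0.12 log units; within the scatter), lies within the scatter, so compound 2 cannot be set apart from compound 1 on these figures.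

Compound 3, `Cc1nn(C)c(N2CCCC2)c1/C=N/OCc1ccc(C(=O)OC(C)(C)C)cc1`, differs from compound 2 by pyrrolidin-1-yl in place of 4-chlorophenoxy on an aromatic carbon. Going by the values given here, the single measured step, a 1.3-fold lower number from compound 1 to compound 2 (0.12 log units; within the scatter), concerns the same aromatic carbon and an exchange of a different pair of groups; it stayed within the scatter. Among the compounds with values here, no measured step involves pyrrolidin-1-yl, so nothing shows that this place responds to a change of group beyond the scatter.

On that basis no step beyond the scatter is expected for compound 3 in this assay, and the expected step is a 1.2-fold higher number from compound 2 to compound 3 (0.07 log units; within the scatter). Compound 3 is estimated at 22 ug/mL, with a range from 10 ug/mL to 48 ug/mL.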

Compound 3, half-maximal inhibitory concentration: 14.4 ug/mL
The estimate for compound 3 lay 1.5-fold (0.18 log units) above the measured number, within the range that was stated.
By their numbers in this assay, from the lowest: compounds 3, 2 and 1 (each within the scatter of the next).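

In this assay, the exchange of 4-chlorophenoxy for pyrrolidin-1-yl gives a 1.3-fold lower number from compound 2 to compound 3 (0.12 log units; within the scatter) and so adds a second step at this aromatic carbon that stays within the scatter. The exchange of 1H-pyrrol-1-yl for pyrrolidin-1-yl gives a 1.7-fold lower number from compound 1 to compound 3 (0.24 log units; within the scatter) and likewise stays within the scatter, so all three groups at this place, including one with a non-aromatic ring and fewer heavy atoms than 4-chlorophenoxy, leave the numbers indistinguishable. No measurement is available that would explain these numbers.

The compounds shown leave open whether any group at this aromatic carbon can produce a step beyond the scatter, for example an open-chain amine, a carboxylic acid or a longer alkyl chain. They also leave open whether changes elsewhere on the shared core would respond differently.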